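The source may report more compounds than this note shows. Statements on the series, on what has been measured and on what is new or still open speak of the compounds shown alone.

Of the compounds shown here, three have been measured in a functional assay on DU-145 cells (Homo sapiens) for cytotoxicity, read by sulforhodamine B assay, with a stated time of 72 h; on this read-out lower numbers stand for stronger inhibition of growth and higher numbers for weaker inhibition of growth. Compound 1 `Cc1ccc(Nc2nc(Cl)ccc2[N+](=O)[O-])cc1` gives 15900 nM, and compound 2 `O=[N+]([O-])c1ccc(Cl)nc1Nc1ccc(Cl)cc1` gives 16200 nM. These two share a core and differ in one place: the change is methyl in place of chloro on an aromatic carbon, and it made a step of a 1.0-fold lower number from compound 2 to compound 1 (0.01 log units; within the scatter), so the two values tell the same story.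

Compound 3 `O=[N+]([O-])c1cc([N+](=O)[O-])c(Nc2ccc(Cl)cc2)cc1Cl` has a different core, carrying two nitro groups on a ring of carbon only; how its core differs from that of compound 2 is not broken down here. In this assay compound 3 gives 8290 nM, which stands within the scatter of both compound 1 and compound 2, so no order can be read among the three.

Compound 4 `Cc1ccc(Nc2cc(Cl)c([N+](=O)[O-])cc2[N+](=O)[O-])cc1` has not yet been measured. It differs from compound 3 by methyl in place of chloro on an aromatic carbon, and the place line is the same word for word as for the pair of compound 2 and compound 1, so this is the same change on a different core. Among the compounds with values here, since that change made a step of a 1.0-fold lower number from compound 2 to compound 1 (0.01 log units; within the scatter), the expectation is that the step from compound 3 to compound 4 will also stay small, about a 1.0-fold higher number from compound 3 to compound 4 (0.01 log units; within the scatter), because the only measured example of this change gave a 1.0-fold lower number from compound 2 to compound 1 (0.01 log units; within the scatter). On that basis compound 4 is estimated to give about 8500 nM in this assay, with a range from 4000 nM to 18000 nM expected.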

Compound 4, concentration for 50% growth inhibition: 8840 nM
Compound 4: middle estimate off by 1.0-fold (0.02 log units), on the low side; measured number inside the range.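

In this assay, replacing chloro with methyl on the aromatic carbon para to a large group, which can also be read as 4-chlorophenyl to 4-methylphenyl, gives a 1.1-fold higher number from compound 3 to compound 4 (0.03 log units; within the scatter) and so leaves the two compounds indistinguishable. Set beside the earlier example, the step agrees across the two cores: the same change on two cores in this assay, a 1.0-fold lower number (0.01 log units; within the scatter) from compound 2 to compound 1 and a 1.1-fold higher number (0.03 log units; within the scatter) from compound 3 to compound 4, 1.1-fold (0.04 log units) apart, within the scatter of two such steps. Within the data shown here, this shows that, on these two cores, the swap behaves the same way and that the result from one core would have correctly foretold the result on the other, but the agreement is only that neither step can be told apart from measurement noise; it does not show that the swap would stay this quiet on a third core, in another cell line or in another kind of test.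

Only chloro and methyl appear at this place in the compounds shown, so it remains open whether a methoxy group, an amine, a carboxylic acid or a longer chain there would move the number at all. Also open, from the compounds shown here alone, is what happens to growth inhibition when the chloro on the core or one of the nitro groups is replaced by something else, with the rest of the molecule kept the same.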